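The source may hold more compounds than are shown below. What is called first, only, known or untested is meant among the compounds shown, and "the series" means these compounds.

Measured so far:
Compound 1 `CC(C)(C)c1cc(/C=C2\CCNC2=O)cc(C(C)(C)C)c1O`: 2.2 mg/kg
Compound 2 `CN1CC/C(=C\c2cc(C(C)(C)C)c(O)c(C(C)(C)C)c2)C1=O`: 3.8 mg/kg

Among the compounds with values here, in a functional assay on the whole organism with Rattus norvegicus as the target (on this read-out higher numbers stand for an effect only at larger amounts of compound and lower numbers for an effect already at smaller amounts), compound 2 gives 3.8 mg/kg, which cannot be told apart from the only other measured number. Compound 3 `CCN1CC/C(=C\c2cc(C(C)(C)C)c(O)c(C(C)(C)C)c2)C1=O` differs from compound 2 by one change, methyl in place of hydrogen on a saturated chain carbon bound to an amide-type nitrogen in a ring, or methyl to ethyl. Within the data shown here, one measured step bears on it, a 1.7-fold higher number from compound 1 to compound 2 (0.24 log units; within the scatter), where a methyl replaced hydrogen on the amide-type nitrogen itself. With that single precedent, no shift beyond the scatter is expected in this assay. The expected step is a 1.1-fold higher number from compound 2 to compound 3 (0.02 log units; within the scatter). For compound 3 the estimated value is 4 mg/kg, with a range from 1.8 mg/kg to 9 mg/kg.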

Compound 3, dose for half-maximal effect: 12 mg/kg
The estimate for compound 3 lay 3.0-fold (0.48 log units) below the measured number; the whole stated range lies below it.
By their numbers in this assay, from the lowest: compounds 1 and 2 (each within the scatter of the next); then compound 3.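

In this assay, going from methyl to ethyl on the amide-type nitrogen gives a 3.2-fold higher number from compound 2 to compound 3 (0.50 log units; beyond the scatter) and so, unlike the methyl step from hydrogen, moves the number beyond the scatter. Ethyl in place of hydrogen on that nitrogen gives a 5.5-fold higher number from compound 1 to compound 3 (0.74 log units; beyond the scatter) in the same direction, so this position does respond to substitution once the group is ethyl. No evidence at hand accounts for this shift. On these data alone, whether a longer chain such as propyl would raise the number further remains open, as does how an amine or a carboxylic acid at the end of such a chain would behave.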